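The source may report more compounds than this note shows. Statements on the series, on what has been measured and on what is new or still open speak of the compounds shown alone.

In a functional assay on MCF7 cells (Homo sapiens) for inhibition, read by CCK-8 assay, with a stated time of 48 h (a higher number here means a weaker inhibitor of growth, a lower number a stronger inhibitor of growth), compound 1 `Cc1ccc(CNc2nc(Nc3ccc(N4CCN(C)CC4)cn3)ncc2Cl)cc1` gives 38100 nM, compound 2 `COc1ccc(CNc2nc(Nc3ccc(N4CCN(C)CC4)cn3)ncc2Cl)cc1` gives 17300 nM and compound 3 `CN1CCN(c2ccc(Nc3ncc(Cl)c(NCc4ccco4)n3)nc2)CC1` gives 21300 nM. Compound 3 therefore falls among these values, but it cannot be separated from either of the others: a 1.8-fold lower number from compound 1 to compound 3 (0.25 log units; within the scatter) and a 1.2-fold higher number from compound 2 to compound 3 (0.09 log units; within the scatter) are both within the scatter. Only a 2.2-fold lower number from compound 1 to compound 2 (0.34 log units; beyond the scatter) goes beyond the scatter, and modestly so.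

Compound 4 `Cc1cc(C)c(Nc2nc(Nc3ccc(N4CCN(C)CC4)cn3)ncc2Cl)c(C)c1` brings a new change: 2,4,6-trimethylphenyl in place of (furan-2-yl)methyl on a nitrogen on an aromatic ring. In words, 2,4,6-trimethylphenyl stands in place of (furan-2-yl)methyl on a nitrogen on an aromatic ring. The closest evidence is the pair of furan-2-yl steps above, and both are small. Going by the values given here, no measured compound carries 2,4,6-trimethylphenyl on that nitrogen, so these steps are only a loose guide. No shift beyond the scatter is expected in this assay, and no direction can be favoured. The estimated step is a 1.1-fold lower number from compound 3 to compound 4 (0.03 log units; within the scatter). For compound 4 the expected value is 20000 nM, with an estimated range from 7000 nM to 50000 nM.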

Compound 4, concentration for 50% growth inhibition: 9470 nM
Compound 4: middle estimate off by 2.1-fold (0.32 log units), on the high side, within the range that was stated.
By their numbers in this assay, from the lowest: compounds 4, 2, 3 and 1 (each within the scatter of the next, the first and the last beyond it).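

In this assay, this nitrogen on an aromatic ring tolerates a 2,4,6-trimethylphenyl group, and replacing a whole group here now gives a shift beyond the scatter: a 2.2-fold lower number from compound 3 to compound 4 (0.35 log units; beyond the scatter) and a 4.0-fold lower number from compound 1 to compound 4 (0.60 log units; beyond the scatter). The comparison with the 4-methoxybenzyl compound is less clear, as a 1.8-fold lower number from compound 2 to compound 4 (0.26 log units; within the scatter) does not separate compound 2 from compound 4, so the new group cannot be ranked above every earlier one. Nothing measured here explains these shifts.

The change also swaps a benzyl or (furan-2-yl)methyl group for a ring held directly on the nitrogen and adds three methyl groups, so the effects of these two differences cannot be told apart. An unsubstituted phenyl or a 2,4,6-trimethylbenzyl group on the same nitrogen would separate them.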